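Spiro Triazole Series: Two Limits, Third Compound Expected Similar

This account rests on a few compounds, and the source may have more. Where it says the series, first, only, none or still open, it means among the compounds named here.

Compound 1 `N#CC1=C(N)Oc2c(c3nc4ccccc4nc3c3ccccc23)C12C(=O)N(Cc1cnnn1-c1ccc(Cl)c(Cl)c1)c1ccccc12`: > 50000 nM
Compound 2 `N#CC1=C(N)Oc2c(N)cc3nc4ccccc4nc3c2C12C(=O)N(Cc1cnnn1-c1ccc([N+](=O)[O-])cc1)c1ccccc12`: > 50000 nM

In a functional assay on HepG2 cells (Homo sapiens) for antiproliferative activity, read by MTT assay, with a stated time of 48 h (on this read-out higher numbers stand for weaker inhibition and lower numbers for stronger inhibition), compound 1 reaches only a limit of the assay, > 50000 nM. Compound 2 likewise gives only a limit, > 50000 nM. Compound 2 thus stands where both values shown sit, at the limit of > 50000 nM in this assay, at which 2 of the 2 values shown sit. Compound 3 `COc1cc(-n2nncc2CN2C(=O)C3(C(C#N)=C(N)Oc4c(N)cc5nc6ccccc6nc5c43)c3ccccc32)c(OC)cc1Cl` differs from compound 2 by 4-chloro-2,5-dimethoxyphenyl in place of 4-nitrophenyl on an aromatic nitrogen. Within the data shown here, no step between measured compounds is known, so the data give no size of step in this assay; the change is expected to yield none beyond the scatter. Compound 3 is estimated at 50000 nM, within 20000 nM to 100000 nM. This estimate means a number no higher from compound 2 to compound 3 (the limit leaves the size open), expected again to appear as a limit.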

Compound 3, half-maximal inhibitory concentration: > 50000 nM
Compound 3: only a limit was reported; the forecaster's own chance of this, stated with the estimate: 80%; the middle value lies on the limit itself.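

In this assay compound 3 gives only a limit, > 50000 nM, so no step can be read between compound 2 and compound 3. The compounds shown leave open what size of change, if any, 4-chloro-2,5-dimethoxyphenyl in place of 4-nitrophenyl brings.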